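The compounds below may be only part of what the source reports. "The series", "measured", "known", "first", "only" and "open" are said of these compounds alone.

Three compounds have so far been measured in an assay on isolated protein for inhibition of malate dehydrogenase, mitochondrial (Sus scrofa), with stated times of 45 min and 30 min; a lower number here means a stronger inhibitor, a higher number a weaker inhibitor:

Compound 1, `O=S(=O)(Nc1ccc(-c2nc3ccccc3o2)cc1)c1ccccc1O`, gives > 63000 nM, a limit of the assay.
Compound 2, `Cc1cccc(S(=O)(=O)Nc2ccc(-c3nc4ccccc4o3)cc2)c1`, gives > 63000 nM, again a limit.
Compound 3, `O=S(=O)(Nc1ccc(-c2nc3ccccc3o2)cc1)c1ccccc1Cl`, gives > 63000 nM, also a limit.

Compound 3 therefore stands where the other two stand: no number was reached for it, only a limit, and the same holds for the two values beside it, as the limit of > 63000 nM in this assay, at which 3 of the 3 values shown sit, sums up. The steps among the measured compounds are a step that the two limits leave unreadable from compound 1 to compound 2, a step that the two limits leave unreadable from compound 1 to compound 3 and a step that the two limits leave unreadable from compound 2 to compound 3; each of them joins two limits, so none of them has a readable size or direction.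

Compound 4, `O=S(=O)(Nc1ccc(-c2nc3ccccc3o2)cc1)c1ccc(O)cc1`, is yet to be measured in this assay. Its change from compound 3 is 4-hydroxyphenyl in place of 2-chlorophenyl on a sulfonyl sulfur. Within the data shown here, none of the measured steps gives a readable size, so there is nothing to show that a change of this kind moves the value beyond the scatter, in either direction; the three limits seen so far are the only guide.

Compound 4 is therefore expected to give about 90000 nM in this assay, most likely reported again as a limit, within a range of 30000 nM to 300000 nM. The step this estimate implies is a step that the limit leaves unreadable from compound 3 to compound 4, which is expected to be unreadable in practice.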

Compound 4, half-maximal inhibitory concentration: > 63000 nM
Compound 4: no number, only a limit (the forecaster's own chance of this, stated with the estimate: 85%); the middle value is on the limit's open side.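

Compound 4 in this assay gives > 63000 nM, a limit and not a number. Its steps from compound 1, compound 2 and compound 3 therefore cannot be read, and one limit holds for the whole set: the limit of > 63000 nM in this assay, at which 4 of the 4 values shown sit. The compounds shown leave open whether changing the group on the sulfonyl sulfur alters inhibition at all, and how strong any of these compounds actually is.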